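The compounds below may be only part of what the source reports. "The series", "measured", "known", "first", "only" and "open" are said of these compounds alone.

In a functional assay on DLD-1 cells (Homo sapiens) for cytotoxicity, with a stated time of 48 h (on this read-out higher numbers stand for weaker inhibition and lower numbers for stronger inhibition), compound 3 `C[S+]([O-])/C=C/c1cc(=O)c2ccccc2o1` gives 8000 nM. This lies within the scatter of compound 1 `CCCCCOc1ccc2oc(/C=C/[S+](C)[O-])cc(=O)c2c1` at 6600 nM and of compound 2 `CC(C)COc1ccc2oc(/C=C/[S+](C)[O-])cc(=O)c2c1` at 5000 nM. Compound 4 `CC(C)CC(=O)Oc1ccc2oc(/C=C/[S+](C)[O-])cc(=O)c2c1` differs from compound 3 in one place: (isobutylcarbonyl)oxy in place of hydrogen on an aromatic carbon, with (isobutylcarbonyl)oxy in place of hydrogen on an aromatic carbon. Going by the values given here, two measured steps bear on this change, as each swaps a chain on that carbon for hydrogen: a 1.2-fold higher number from compound 1 to compound 3 (0.08 log units; within the scatter) and a 1.6-fold higher number from compound 2 to compound 3 (0.20 log units; within the scatter). Among the compounds with values here, both stay within the scatter, although no measured compound carries the entering group itself. In this assay the expected result is a 1.3-fold lower number from compound 3 to compound 4 (0.12 log units; within the scatter), so no shift beyond the scatter is anticipated. For compound 4 the estimated value is 6000 nM, with an expected range from 2500 nM to 14000 nM.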

Compound 4, half-maximal inhibitory concentration: 6100 nM
Estimate against measurement, compound 4: 1.0-fold (0.01 log units) below; the measured number falls inside the stated range.
By their numbers in this assay, from the lowest: compounds 2, 4, 1 and 3 (each within the scatter of the next).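

In this assay, going by these compounds alone, placing (isobutylcarbonyl)oxy on this aromatic carbon, the first group here with a carbonyl, stays within the scatter of hydrogen, with a 1.3-fold lower number from compound 3 to compound 4 (0.12 log units; within the scatter). Changing the chain on that oxygen also stays within the scatter: isobutylcarbonyl for isobutyl gives a 1.2-fold higher number from compound 2 to compound 4 (0.09 log units; within the scatter), and isobutylcarbonyl for pentyl gives a 1.1-fold lower number from compound 1 to compound 4 (0.03 log units; within the scatter). No available evidence explains why these groups give such similar numbers. On these data alone, whether an amine, a carboxylic acid or a much longer chain at this position would shift the number beyond the scatter remains open.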